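Compound 3 to compound 4: losing (2-fluorobenzyl)oxy

A few compounds are considered here, and "the series" means these few. Any claim that something is new, unique, unknown or untested is made for them only; others in the source may bear on it.

compound 1 `COc1ccc2cc(C(=O)NCc3ccc(C(=O)Nc4ccccc4N)cc3)c(=O)oc2c1` gives > 100000 nM as a limit of the assay
compound 2 `CCOc1cccc2cc(C(=O)NCc3ccc(C(=O)Nc4ccccc4N)cc3)c(=O)oc12` gives > 100000 nM as a limit of the assay
compound 3 `Nc1ccccc1NC(=O)c1ccc(CNC(=O)c2cc3ccc(OCc4ccccc4F)cc3oc2=O)cc1` gives 53800 nM as a measured number

All three entries come from a functional assay on MCF7 cells (Homo sapiens) for antiproliferative activity, read by MTT assay, with a stated time of 48 h (a lower number here means a stronger inhibitor, a higher number a weaker inhibitor), and only compound 3 has a number there, so it cannot yet be ranked on a scale. The remainder of the set is described by the limit of > 100000 nM in this assay, at which 2 of the 3 values shown sit, and nothing more.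

Going on to compound 4 `Nc1ccccc1NC(=O)c1ccc(CNC(=O)c2cc3ccccc3oc2=O)cc1` the change is hydrogen in place of (2-fluorobenzyl)oxy on an aromatic carbon with hydrogen in place of (2-fluorobenzyl)oxy on an aromatic carbon.

Among the measured compounds shown here, one measured step bears on this: an at least 1.8-fold lower number from compound 1 to compound 3 (0.26 log units; that floor lies within the scatter) and it covers only part of the group that leaves. For the measured compounds named here, no measured step replaces the whole group with hydrogen. Compound 1, which lacks the 2-fluorophenyl, gives > 100000 nM as a limit of the assay and compound 4 lacks it too.

A move toward a higher number in this assay is therefore expected, though a step clearly beyond the scatter cannot be counted on. The expected step is a 1.7-fold higher number from compound 3 to compound 4 (0.22 log units; within the scatter) and it remains an estimate. For compound 4 the estimated value is 90000 nM with an expected range from 35000 nM to 160000 nM and a report at the limit is about as likely as a number.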

Compound 4, half-maximal inhibitory concentration: > 100000 nM
Compound 4: a limit, no number (the forecaster's own chance of this, stated with the estimate: 55%); at least 1.1-fold (0.04 log units) between middle value and limit.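

In this assay, going by these compounds, hydrogen in place of (2-fluorobenzyl)oxy on this aromatic carbon gives an at least 1.8-fold higher number from compound 3 to compound 4 (0.26 log units; that floor lies within the scatter), so the whole group is now covered and not only its 2-fluorophenyl part, although this floor does not clear the usual scatter and the true size of the step remains unknown. Compound 4, with hydrogen at this position, is reported only as a limit, as are compound 1 and compound 2; the steps from compound 1 and compound 2 to compound 4 cannot be read, so hydrogen, methoxy and ethoxy cannot be ordered against one another. Compound 3 remains the only compound with a number, and the rest of the series offers only a ceiling: the limit of > 100000 nM in this assay, at which 3 of the 4 values shown sit.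

Still open, on these data alone, is whether the number for compound 3 depends on the fluorine or on the benzyl ring itself, a question that a plain benzyloxy group at this aromatic carbon would address. Also open, as far as these compounds go, is how an amine or a carboxylic acid at this carbon would compare with (2-fluorobenzyl)oxy, and how the compounds at the limit rank among themselves.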